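Swapping a benzyl ether for a branched alkyl ether

The source may hold more compounds than are shown below. What is called first, only, known or untested is meant among the compounds shown, and "the series" means these compounds.

Compound 2 `O=C(/C=C/c1ccc(O)cc1)c1c(O)cccc1OCc1ccccc1` was tested in a functional assay on HCT-15 cells (Homo sapiens) for antiproliferative activity, read by sulforhodamine B assay; a higher number here means a weaker inhibitor of growth, a lower number a stronger inhibitor of growth. Compound 2 sits at a limit there: it gives > 30000 nM, which is the limit of the measurement and not a number. The same holds for compound 1 `COc1cccc(OCCC(C)(C)C)c1C(=O)/C=C/c1ccc(O)cc1`, which in this assay also gives > 30000 nM, again a limit. Among the measured compounds shown here, compound 3 `CC(C)(C)CCOc1cccc(O)c1C(=O)/C=C/c1ccc(C(=O)O)cc1` is the one member of this small set with a genuine number, giving 2170 nM in this assay. Because (the limit of > 30000 nM in this assay, at which 2 of the 3 values shown sit), two of the three results shown offer no scale of their own, and no step between two measured compounds can be drawn from them.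

Compound 4 `CCC(CC)COc1cccc(O)c1C(=O)/C=C/c1ccc(O)cc1` is not yet measured. It differs from compound 2 in one place, (pentan-3-yl in place of phenyl on a saturated chain carbon bound to an oxygen on an aromatic ring); cut one bond further out, the change reads benzyloxy to 2-ethylbutoxy. With the chain motif of compound 3 in mind, but with compound 2 starting at a limit, the estimated step from compound 2 to compound 4 is an at least 1.5-fold lower number from compound 2 to compound 4 (0.17 log units; that floor lies within the scatter), leaning toward stronger growth inhibition but without certainty that a number will appear. For compound 4 in this assay the expected value is 20000 nM, with a range from 5000 nM to 40000 nM.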

Compound 4, concentration for 50% growth inhibition: 3420 nM
Beside the measured number, compound 4's estimate is 5.8-fold (0.77 log units) above it, and the stated range ends above it.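

In this assay, among the compounds shown here, one change at this place is enough to move a compound off the limit, and it is the first step that can be read in this set: pentan-3-yl in place of phenyl on a saturated chain carbon bound to an oxygen on an aromatic ring gives an at least 8.7-fold lower number from compound 2 to compound 4 (0.94 log units; beyond the scatter). The step also shows that a measurable value at this place does not depend on an aromatic ring there, as the 2-ethylbutoxy group of compound 4 has no ring at all. Going by these compounds, only a floor can be given for the step, and its true size stays unknown because compound 2 sits at a limit: the limit of > 30000 nM in this assay, at which 2 of the 4 values shown sit.

What the compounds shown leave open is whether the branch of the 2-ethylbutyl chain matters or simply the loss of the phenyl ring, a question that an unbranched hexyl chain or a cyclohexyl ring at the same place would address. On these data alone, it also remains open how far this place tolerates a charged or polar end, such as an amine or a carboxylic acid at the end of the chain.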